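The source may report more compounds than this note shows. Statements on the series, on what has been measured and on what is new or still open speak of the compounds shown alone.

Notes on the series. Compound 1 `O=C(CN1CCN(c2nnc(Cc3ccccc3)c3ccccc23)CC1)Nc1ccc(F)c(F)c1` gives 10100 nM in a functional assay on A549 cells (Homo sapiens) for cytotoxicity, read by MTT assay, with a stated time of 72 h; a lower number here means a stronger inhibitor, a higher number a weaker inhibitor. Compound 2 `Cc1cccc(Cl)c1NC(=O)CN1CCN(c2nnc(Cc3ccccc3)c3ccccc23)CC1` gives 7420 nM in this assay; the step of a 1.4-fold lower number from compound 1 to compound 2 (0.13 log units; within the scatter) is the change (2-chloro-6-methylphenyl in place of 3,4-difluorophenyl on an amide-type nitrogen). Compound 3 `O=C(CN1CCN(c2nnc(Cc3ccncc3)c3ccccc23)CC1)Nc1ccc(F)c(F)c1` gives 3790 nM in this assay, the step of a 2.7-fold lower number from compound 1 to compound 3 (0.43 log units; beyond the scatter) coming from the change (pyridin-4-yl in place of phenyl on a saturated chain carbon bound to an aromatic carbon). Compound 3 has the lowest number of the three measured, though its gap to compound 2 is within the scatter.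

Compound 4 `Cc1cccc(Cl)c1NC(=O)CN1CCN(c2nnc(Cc3ccncc3)c3ccccc23)CC1` is not yet measured. It differs from compound 3 by 2-chloro-6-methylphenyl in place of 3,4-difluorophenyl on an amide-type nitrogen, the same change that was measured as a 1.4-fold lower number from compound 1 to compound 2 (0.13 log units; within the scatter); the two cores differ by pyridin-4-yl in place of phenyl on a saturated chain carbon bound to an aromatic carbon. Within the data shown here, the place of the change is the same in both pairs, so a step of similar size is expected, a 1.4-fold lower number from compound 3 to compound 4 (0.15 log units; within the scatter), resting on the single earlier step of a 1.4-fold lower number from compound 1 to compound 2 (0.13 log units; within the scatter). Compound 4 is thus estimated at 2700 nM in this assay, with a range of 1200 nM to 6000 nM.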

Compound 4, half-maximal inhibitory concentration: 7190 nM
For compound 4 the middle estimate is 2.7-fold (0.43 log units) below the measured one; the whole stated range lies below it.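

In this assay the amide-side change now reads a 1.9-fold higher number from compound 3 to compound 4 (0.28 log units; within the scatter), and the change to pyridin-4-yl reads a 1.0-fold lower number from compound 2 to compound 4 (0.01 log units; within the scatter). Carried to the second core, 2-chloro-6-methylphenyl in place of 3,4-difluorophenyl does not differ measurably from its earlier step: the same change on two cores in this assay, a 1.4-fold lower number (0.13 log units; within the scatter) from compound 1 to compound 2 and a 1.9-fold higher number (0.28 log units; within the scatter) from compound 3 to compound 4, 2.6-fold (0.41 log units) apart, within the scatter of two such steps. Among these compounds, the change to pyridin-4-yl likewise shows no measurable dependence on the core, yet with only two steps per change this does not establish that either change transfers reliably, only that any core dependence cannot be told from the scatter: the same change on two cores in this assay, a 2.7-fold lower number (0.43 log units; beyond the scatter) from compound 1 to compound 3 and a 1.0-fold lower number (0.01 log units; within the scatter) from compound 2 to compound 4, 2.6-fold (0.41 log units) apart, within the scatter of two such steps.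

The compounds shown leave open how a pyridin-3-yl group in place of pyridin-4-yl, or a cyclohexyl group on the amide-type nitrogen, would behave across these two cores.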